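Fluoro for methyl on the shared core

The source may hold more compounds than are shown below. What is called first, only, known or untested is meant among the compounds shown, and "the series" means these compounds.

Measured compounds:
compound 1 `CCCS(=O)(=O)c1ccc(F)c(C#Cc2cc(Cl)ccc2OCC(=O)O)c1`: 3.4 nM
compound 2 `CCCS(=O)(=O)c1ccc(C)c(C#Cc2cc(Cl)ccc2OC(C)C(=O)O)c1`: 1.2 nM

In an assay on CHO cells for displacement of a labelled ligand from prostaglandin D2 receptor 2 (Homo sapiens), read by scintillation counting (a lower number here means a stronger inhibitor, a higher number a weaker inhibitor), compound 2 gives the lowest of the two numbers shown; compound 1 gives a higher number, and that gap lies beyond the scatter. Compound 3 `CCCS(=O)(=O)c1ccc(F)c(C#Cc2cc(Cl)ccc2OC(C)C(=O)O)c1` differs from compound 2 in one place: fluoro in place of methyl on an aromatic carbon. Among the compounds with values here, compound 1 carries a fluoro at the same place, but compound 1 and compound 2 also differ elsewhere, so no single step between measured compounds isolates this exchange, and what compound 1 and compound 2 show cannot be read as the effect of the fluoro alone. One heavy atom leaves and one enters, with no change in donors, acceptors or charge, so no step beyond the scatter is expected in either direction in this assay. Compound 3 is therefore expected at 2 nM, within 0.8 nM to 6 nM, a step of a 1.7-fold higher number from compound 2 to compound 3 (0.22 log units; within the scatter) that is estimated to stay inside the scatter.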

Compound 3, inhibition constant: 3 nM
Compound 3: middle estimate off by 1.5-fold (0.18 log units), on the low side; the measured number falls inside the stated range.
By their numbers in this assay, from the lowest: compound 2; then compounds 3 and 1 (each within the scatter of the next).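

In this assay, the exchange on the aromatic carbon para to the propylsulfonyl group can now be read alone: fluoro in place of methyl gives a step beyond the scatter (a 2.5-fold higher number from compound 2 to compound 3 (0.40 log units; beyond the scatter)), with methyl holding the lower number. The second exchange, methyl in place of hydrogen on the saturated chain carbon bound to a carbonyl carbon and an oxygen on an aromatic ring, stays within the scatter when this position carries fluoro (a 1.1-fold lower number from compound 1 to compound 3 (0.05 log units; within the scatter)). Nothing available explains the size of either step.

Going by these compounds, whether that chain methyl matters as little when the aromatic carbon carries methyl remains open. So does how chloro, methoxy or a nitrile at this aromatic carbon, or an ethyl on the chain carbon, would compare.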